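The source may report more compounds than this note shows. Statements on the series, on what has been measured and on what is new or still open speak of the compounds shown alone.

Of the compounds shown here, three built on one shared core have been tested in a functional assay on A549 cells (Homo sapiens) for antiproliferative activity, read by MTT assay, with a stated time of 72 h; a lower number here means a stronger inhibitor, a higher number a weaker inhibitor. Compound 1 `COc1cc(F)c(NC(=O)c2ccncc2)cc1Nc1nccc(-c2cn(C)c3ccccc23)n1` gives 4200 nM, compound 2 `COc1cc(F)c(NC(=O)c2ncccn2)cc1Nc1nccc(-c2cn(C)c3ccccc23)n1` gives 8400 nM, and compound 3 `COc1cc(N(C)CCN(C)C)c(NC(=O)c2ccncc2)cc1Nc1nccc(-c2cn(C)c3ccccc23)n1` gives 10400 nM. Within the data shown here, compound 3 carries the highest number of the three, but its gap to compound 2 lies within the scatter, so only the step from compound 1 stands out: a 2.5-fold higher number from compound 1 to compound 3 (0.39 log units; beyond the scatter). Compound 4 `COc1cc(N(C)CCN(C)C)c(NC(=O)c2ccnc(O)c2)cc1Nc1nccc(-c2cn(C)c3ccccc23)n1` differs from compound 3 by a single change: hydroxy in place of hydrogen on an aromatic carbon. Among the measured compounds shown here, no measured step tests a hydroxy group. The nearest comparison, a 2.0-fold higher number from compound 1 to compound 2 (0.30 log units; within the scatter), altered the same carbonyl-bound ring and stayed within the scatter. A small step, in no firm direction, is therefore expected: a 1.0-fold lower number from compound 3 to compound 4 (0.02 log units; within the scatter). Compound 4 is estimated at 10000 nM, with a range from 3000 nM to 33000 nM.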

Compound 4, half-maximal inhibitory concentration: 11200 nM
Estimate against measurement, compound 4: 1.1-fold (0.05 log units) below, and the stated range covers the measured number.
By their numbers in this assay, from the lowest: compounds 1, 2, 3 and 4 (each within the scatter of the next, the first and the last beyond it).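

In this assay, hydroxy on the aromatic carbon next to the ring nitrogen of the pyridin-4-yl group gives a 1.1-fold higher number from compound 3 to compound 4 (0.03 log units; within the scatter) and so produces no readable change. This first test of the position shows that the 2-hydroxypyridin-4-yl amide keeps the number of the parent pyridin-4-yl amide on this background, with no gain in activity. Nothing available explains this result.

As far as these compounds go, whether an amine or a carboxylic acid on this carbon would move the number remains open. So does whether hydroxy would behave the same way on compound 1, which carries fluoro instead of the (2-(dimethylamino)ethyl)(methyl)amino group.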